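Toward compound 4: cytotoxicity of three precursors

The source may report more compounds than this note shows. Statements on the series, on what has been measured and on what is new or still open speak of the compounds shown alone.

Compound 1 `CCOC(=O)CCCCCOc1cccc(CN(C(=O)c2ccc(-c3cccc4ccccc34)cc2)C(C)C)c1` gives in an ADME assay on BJ cells (Homo sapiens) for cytotoxicity, read by CellTiter-Glo and resazurin assay, with a stated time of 72 h (a higher number here means that more compound is needed for the effect, a lower number that less compound is needed), only a limit, > 26000 nM.
Compound 2 `CCOC(=O)CCCCCOc1cccc(CN(C(=O)c2ccc(-c3cccnc3)cc2)C(C)C)c1` gives in this assay only a limit, > 26000 nM.
Compound 3 `CCOC(=O)CCCCCOc1cccc(CN(C(=O)c2ccc(-c3cc(OC)cc(OC)c3)cc2)C(C)C)c1` gives in this assay only a limit, > 26000 nM.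

Compound 3 therefore stands nowhere in particular on these numbers: its value is a limit, and the same holds for the other two, as the limit of > 26000 nM in this assay, at which 3 of the 3 values shown sit, shows. The steps a step that the two limits leave unreadable from compound 1 to compound 3 and a step that the two limits leave unreadable from compound 2 to compound 3 are accordingly unreadable, and so is a step that the two limits leave unreadable from compound 1 to compound 2.

The next change is bromo in place of 3,5-dimethoxyphenyl on an aromatic carbon, which gives compound 4 `CCOC(=O)CCCCCOc1cccc(CN(C(=O)c2ccc(Br)cc2)C(C)C)c1`. For the measured compounds named here, no measured step bears readably on it, so in this assay no step beyond the scatter is expected, and the estimated step of a number no higher from compound 3 to compound 4 (the limit leaves the size open) is essentially none. Compound 4 is expected to give 26000 nM, within 13000 nM to 60000 nM.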

Compound 4, half-maximal effective concentration: > 26000 nM
Compound 4: no number, only a limit; the forecaster's own chance of this, stated with the estimate: 85%; the middle value lies on the limit itself.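

No step can be read between compound 4 and compound 1, compound 2 or compound 3, as each gives only a limit, the same one: the limit of > 26000 nM in this assay, at which 4 of the 4 values shown sit.

The compounds shown leave open what concentration of any of them produces the effect in this assay, and whether the changed group alters it at all.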